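A few compounds are considered here, and "the series" means these few. Any claim that something is new, unique, unknown or untested is made for them only; others in the source may bear on it.

Compound 3 `O=C1C=CC2(C=C1)OCC(=O)N2c1nc(-c2cccc3ccccc23)nn1-c1ccccc1` gives 50 nM in a functional assay on MDA-MB-231 cells (Homo sapiens) for antiproliferative activity, with a stated time of 5 days; a higher number here means a weaker inhibitor, a lower number a stronger inhibitor. That places compound 3 level with compound 1 `O=C1C=CC2(C=C1)OCC(=O)N2c1nc(-c2ccc3ccccc3c2Br)nn1-c1ccccc1`, which gives 50 nM, and the two together hold the lowest numbers of the three measured; compound 2 `CC1OC2(C=CC(=O)C=C2)N(c2nc(-c3cccc4ccccc34)nn2-c2ccccc2)C1=O` gives 100 nM, the highest. Compound 4 `O=C1C=CC2(C=C1)OCC(=O)N2c1nc(-c2ccc(F)c3ccccc23)nn1-c1ccccc1` differs from compound 3 by a single change: fluoro in place of hydrogen on an aromatic carbon. The closest measured step is a swap on the same aromatic ring system, no change at the digits printed from compound 1 to compound 3 (within the scatter), and it moved nothing beyond the scatter. The other step, a 2.0-fold lower number from compound 2 to compound 3 (0.30 log units; within the scatter), concerns a saturated ring carbon elsewhere and is also within the scatter. A small change on the naphthyl ring is therefore expected to leave the number about where it is, so no change at the digits printed from compound 3 to compound 4 (within the scatter) is the expected step. Compound 4 is estimated at 50 nM, within 25 nM to 100 nM.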

Compound 4, half-maximal inhibitory concentration: 80 nM
For compound 4 the middle estimate is 1.6-fold (0.20 log units) below the measured one; the measured number falls inside the stated range.
By their numbers in this assay, from the lowest: compounds 1, 3, 4 and 2 (each within the scatter of the next).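

Fluoro in place of hydrogen on this aromatic carbon, para to a large group, gives a 1.6-fold higher number from compound 3 to compound 4 (0.20 log units; within the scatter), so this position accepts a single fluorine without a change that stands clear of the scatter. Replacing the whole aryl group, with 4-fluoronaphthalen-1-yl in place of 1-bromonaphthalen-2-yl, gives a 1.6-fold higher number from compound 1 to compound 4 (0.20 log units; within the scatter), which also stays within the scatter. No measurement at hand explains either step. Going by these compounds, whether an amine or a methoxy group on this same carbon would also leave the number in place remains open.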